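Methoxy removal across two related cores

This account rests on a few compounds, and the source may have more. Where it says the series, first, only, none or still open, it means among the compounds named here.

Compound 1 `COc1ccc(OC)c(C2CC(c3ccco3)=NN2C(C)=O)c1` and compound 2 `COc1cc(OC)c(C2CC(c3ccco3)=NN2C(C)=O)cc1OC` share one core, while compound 3 `COc1ccc(C2CC(c3cccc4ccccc34)=NN2C(C)=O)c(OC)c1OC` is built on a different one. In a functional assay on PC-3 cells (Homo sapiens) for cytotoxicity, read by sulforhodamine B assay, with a stated time of 48 h (a higher number here means a weaker inhibitor, a lower number a stronger inhibitor), compound 1 gives 11200 nM, compound 2 gives 8980 nM and compound 3 gives 1220 nM. Compound 3 thus holds the lowest of the three numbers, and its steps to compound 2 and to compound 1 both lie beyond the scatter. How the core of compound 3 differs from the core of compound 2 is not broken down here.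

Compound 4 `COc1ccc(C2CC(c3cccc4ccccc34)=NN2C(C)=O)cc1OC` remains to be measured. From compound 3 to compound 4 the change is hydrogen in place of methoxy on an aromatic carbon. The same kind of change separates compound 2 from compound 1, namely (hydrogen in place of methoxy on an aromatic carbon); the surroundings are not identical, since in compound 3 the place is ortho to a large group, whereas in compound 2 it is para to a large group.

In this assay the step from compound 3 to compound 4 is expected to be a 1.2-fold higher number from compound 3 to compound 4 (0.09 log units; within the scatter), an estimate that rests on the earlier change having given a 1.2-fold higher number from compound 2 to compound 1 (0.10 log units; within the scatter), with some extra width allowed for the different place. Compound 4 is accordingly expected to give about 1500 nM in this assay, with the estimate spanning from 600 nM to 4000 nM.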

Compound 4, half-maximal inhibitory concentration: 2010 nM
For compound 4 the middle estimate is 1.3-fold (0.13 log units) below the measured one; low and high end bracket the measured number.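

In this assay, the new step, hydrogen in place of methoxy on an aromatic carbon, is a 1.6-fold higher number from compound 3 to compound 4 (0.22 log units; within the scatter). Set beside the earlier case, the change carries over between the two cores with no difference in size that can be told from the scatter: the same change on two cores in this assay, a 1.2-fold higher number (0.10 log units; within the scatter) from compound 2 to compound 1 and a 1.6-fold higher number (0.22 log units; within the scatter) from compound 3 to compound 4, 1.3-fold (0.12 log units) apart, within the scatter of two such steps. Among the compounds shown here, this shows agreement between two small steps, one of them taken at a place ortho to a large group, but with only two pairs it sets no rule for the series and does not show that a methoxy group can be dropped from any place on these rings without consequence in this cell assay.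

Going by these compounds, all four compounds carry only methoxy groups on the ring where the change falls, so it remains open how a hydroxyl group, a chlorine atom or an amine at the same place would compare with either methoxy or hydrogen. Also open is whether the step stays this small once further methoxy groups leave the same ring, or on a core other than the two shown here.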